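The source may hold more compounds than are shown below. What is called first, only, known or untested is meant among the compounds shown, and "the series" means these compounds.

Measured so far

Compound 1, `OC[C@H]1O[C@@H](n2cnc3cnccc32)[C@H](O)[C@@H]1O`: in a functional assay on EL4 cells (Mus musculus) for inhibition, tested at 100 uM (on this read-out lower numbers stand for less inhibition and higher numbers for more inhibition at the one concentration tested (going by the name of the read-out)), compound 1 gives < 5%; < 5% (2 entries), both entries being a limit of the assay.
Compound 2, `OC[C@H]1O[C@@H](n2cnc3cnccc32)C[C@@H]1O`: in this assay compound 2 gives < 5%, a limit of the assay.
Compound 3, `[N-]=[N+]=Nc1nccc2ncn([C@H]3C[C@H](O)[C@@H](CO)O3)c12`: in this assay compound 3 gives < 5%, a limit of the assay.

For the measured compounds named here, compound 2 therefore stands at the floor of what the series shows: no compound has produced a number, and nothing separates the three on this read-out. Going by the values given here, the only common feature is the limit of < 5% in this assay, at which 2 of the 3 values shown sit, so no step between measured compounds can be drawn, and no trend can be claimed.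

The next compound is compound 4, `OC[C@H]1O[C@@H](n2cnc3c(S)nccc32)C[C@@H]1O`. Relative to compound 2 the change is sulfanyl in place of hydrogen on an aromatic carbon. Among the compounds with values here, with no measured step to lean on, the expectation rests on compound 2 alone and its limit < 5% in this assay.

The step from compound 2 to compound 4 is expected to be a number no lower from compound 2 to compound 4 (the limit leaves the size open), that is, no movement beyond the scatter. For compound 4 the estimate in this assay is 5%, within a range from 0% to 25%, most likely reported again as a limit.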

Compound 4, a percentage reported as inhibition, at one concentration (the size of the read-out at that concentration, not a potency): < 5%
Compound 4: no number, only a limit; the forecaster's own chance of this, stated with the estimate: 70%; the middle value lies on the limit itself.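

Compound 2 and compound 4 both give only limits in this assay, so the step between them cannot be read: the limit of < 5% in this assay, at which 3 of the 4 values shown sit. The compounds shown leave open whether sulfanyl in place of hydrogen changes inhibition at all, and whether any change to the shared core yields a readable number.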